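The source may report more compounds than this note shows. Statements on the series, on what has been measured and on what is new or still open speak of the compounds shown alone.

Compound 1 `CN(C)CCCNc1nc(-c2ccc(NC(=O)Nc3ccccc3Cl)cc2)nc2ccsc12` gives 590 nM in a functional assay on MDA-MB-231 cells (Homo sapiens) for cytotoxicity, read by MTT assay, with a stated time of 72 h; a lower number here means a stronger inhibitor, a higher number a weaker inhibitor. Compound 2 `CN(C)CCCNc1nc(-c2ccc(NC(=O)Nc3ccc(Cl)cc3Cl)cc2)nc2ccsc12` carries chloro in place of hydrogen on an aromatic carbon; in this assay compound 2 gives 1860 nM, so a 3.2-fold higher number from compound 1 to compound 2 (0.50 log units; beyond the scatter). Compound 3 `CN(C)CCNc1nc(-c2ccc(NC(=O)Nc3ccccc3Cl)cc2)nc2ccsc12` gives 550 nM in this assay, and a 1.1-fold lower number from compound 1 to compound 3 (0.03 log units; within the scatter). Compound 4 `CN(C)CCNc1nc(-c2ccc(NC(=O)Nc3ccc(Cl)cc3Cl)cc2)nc2ccsc12` is not yet measured. Among the compounds with values here, it differs from compound 3 by chloro in place of hydrogen on an aromatic carbon, the same change at the same place as the one that turned compound 1 into compound 2; the two cores differ by dimethylamino in place of (dimethylamino)methyl on a saturated chain carbon, two bonds along the chain from a nitrogen on an aromatic ring. Since that core difference left the numbers of compound 1 and compound 3 within the scatter, the earlier step is taken as the guide. The step from compound 3 to compound 4 is expected to be a 3.2-fold higher number from compound 3 to compound 4 (0.50 log units; beyond the scatter), resting on a 3.2-fold higher number from compound 1 to compound 2 (0.50 log units; beyond the scatter). Compound 4 is therefore estimated at 1750 nM in this assay, expected to fall between 850 nM and 3600 nM.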

Compound 4, half-maximal inhibitory concentration: 2450 nM
Compound 4: the middle estimate sits 1.4-fold (0.15 log units) below what was measured; the range from low to high includes it.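

Going from 2-chlorophenyl to 2,4-dichlorophenyl gives a 4.5-fold higher number from compound 3 to compound 4 (0.65 log units; beyond the scatter) in this assay, and this step carries over from one core to the other with no gap beyond the scatter: the same change on two cores in this assay, a 3.2-fold higher number (0.50 log units; beyond the scatter) from compound 1 to compound 2 and a 4.5-fold higher number (0.65 log units; beyond the scatter) from compound 3 to compound 4, 1.4-fold (0.15 log units) apart, within the scatter of two such steps. The core difference, read on the 2,4-dichlorophenyl compounds as a 1.3-fold higher number from compound 2 to compound 4 (0.12 log units; within the scatter), likewise matches its earlier reading: the same change on two cores in this assay, a 1.1-fold lower number (0.03 log units; within the scatter) from compound 1 to compound 3 and a 1.3-fold higher number (0.12 log units; within the scatter) from compound 2 to compound 4, 1.4-fold (0.15 log units) apart, within the scatter of two such steps. Within the data shown here, this shows that the two changes act consistently across these four compounds, but it covers only two closely related cores and one added chloro group, and it does not show that the step would carry to other cores.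

Going by these compounds, it remains open whether fluoro, methoxy or a carboxylic acid in place of that chloro would follow the same course. A morpholine in place of the dimethylamino group, or a longer chain, is also an open case.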